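Chain shortening on the dimethylamino pyridinol series

The compounds below may be only part of what the source reports. "The series", "measured", "known", "first", "only" and "open" are said of these compounds alone.

Compound 3 `CCCCCCCCCCCCCCCCCCCc1nc(N(C)C)c(C)c(C)c1O` gives 7% in a functional assay on cells (Lymphocyte, Homo sapiens), read by trypan blue exclusion, with a stated time of 16 h, tested at 0.5 uM (a lower number here means a weaker effect, a higher number a stronger effect of the compound at the concentration tested), the lowest of the three numbers in hand. Compound 2 `Cc1c(N(C)C)nc(CCCCCCCCCCO)c(O)c1C` gives 36%, and compound 1 `CCCCCCCCCCCCCCCCc1nc(N2CCC2)c(C)c(C)c1O` gives 82%; compound 1 and compound 3 differ in two places, so their values are only set side by side.

Compound 4 `CCCCCCCCCCCCCCCCc1nc(N(C)C)c(C)c(C)c1O` is the next member. Its difference from compound 3 is hydrogen in place of propyl on a saturated chain carbon, ten or more bonds along the chain from an aromatic carbon.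

Within the data shown here, the only single-point step measured so far is a number 29 percentage points lower from compound 2 to compound 3 (beyond the scatter), and it concerns a change at the far end of the chain rather than a removal of chain carbons, so it bears on the present step only loosely. Among the measured compounds shown here, no measured pair isolates a propyl removal. Compound 1, which carries the same chain length as compound 4 but a different amine, stands far higher than compound 3, which leaves the direction open but leaves room for a rise.

Compound 4 is therefore expected to sit at 40%, within 8% to 75%, which amounts to an expected step of a number 33 percentage points higher from compound 3 to compound 4 (beyond the scatter).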

Compound 4, a percentage reported as activity, at one concentration (the size of the read-out at that concentration, not a potency): 78%
Beside the measured number, compound 4's estimate is 38 percentage points below it; the measured number lies above the stated range.
By their numbers in this assay, from the lowest: compound 3; then compound 2; then compounds 4 and 1 (each within the scatter of the next).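

In this assay the chain end proves decisive with the dimethylamino group held fixed: hydrogen in place of propyl gives a number 71 percentage points higher from compound 3 to compound 4 (beyond the scatter), and hexyl in place of hydroxy gives a number 42 percentage points higher from compound 2 to compound 4 (beyond the scatter), whereas nonyl in place of hydroxy gave a number 29 percentage points lower from compound 2 to compound 3 (beyond the scatter), so among compounds 2, 3 and 4 the two chain extensions run in opposite directions. On the amine side, dimethylamino in place of azetidin-1-yl on an aromatic carbon gives a number 4 percentage points lower from compound 1 to compound 4 (within the scatter), so the two amines are not told apart at this chain length. No evidence on why the chain end has this effect is available.

Open, as far as these compounds go, is how the number runs for heptyl or octyl in place of hydroxy at this chain position, and whether a carboxylic acid at the chain end reads like hydroxy. Also open, from the compounds shown here alone, is whether pyrrolidin-1-yl on the aromatic carbon would match dimethylamino and azetidin-1-yl.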